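The source may report more compounds than this note shows. Statements on the series, on what has been measured and on what is new or still open speak of the compounds shown alone.

Compound 1 `CN(C)C(=O)c1cc2cnc(Nc3ccc(NC(=O)C4(C(=O)Nc5ccccc5)CC4)cc3)nc2n1C1CCCC1` gives 106% in a functional assay on SiHa cells (Homo sapiens) for inhibition, read by CCK-8 assay, with a stated time of 72 h, tested at 10 uM (on this read-out higher numbers stand for more inhibition of growth at the one concentration tested and lower numbers for less inhibition of growth), the highest of the three numbers at hand. Compound 2 `CN(C)C(=O)c1cc2cnc(Nc3ccc(NC(=O)C4(C(=O)Nc5ccc(Br)cc5)CC4)cc3)nc2n1C1CCCC1` gives 98.8%, and compound 3 `CN(C)C(=O)c1cc2cnc(Nc3ccc(NC(=O)C4(C(=O)Nc5ccc(Cl)c(C(F)(F)F)c5)CC4)cc3)nc2n1C1CCCC1` gives 61.1%. Compound 4 `CN(C)C(=O)c1cc2cnc(Nc3ccc(NC(=O)C4(C(=O)Nc5cccc(Br)c5)CC4)cc3)nc2n1C1CCCC1` differs from compound 1 by bromo in place of hydrogen on an aromatic carbon. The closest comparison is the step of a number 7.2 percentage points lower from compound 1 to compound 2 (within the scatter), where a bromo entered the same ring at a different place. The large drop a number 44.9 percentage points lower from compound 1 to compound 3 (beyond the scatter) involved a 4-chloro-3-(trifluoromethyl)phenyl and does not bear directly on a single bromo. A bromo alone therefore is expected to leave the number near compound 1, with no step beyond the scatter: the expected change is a number 8 percentage points lower from compound 1 to compound 4 (within the scatter). Compound 4 is estimated at 98%, in the range 80% to 110%.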

Compound 4, percent growth inhibition at one concentration: 92.5%
For compound 4 the middle estimate is 5.5 percentage points above the measured one, within the range that was stated.
By their numbers in this assay, from the lowest: compound 3; then compounds 4, 2 and 1 (each within the scatter of the next, the first and the last beyond it).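

In this assay, a single bromo at this place carries a measurable cost (a number 13.5 percentage points lower from compound 1 to compound 4 (beyond the scatter)), whereas the step to the 4-bromophenyl compound stayed within the scatter. The two bromophenyl compounds themselves cannot be told apart (a number 6.3 percentage points lower from compound 2 to compound 4 (within the scatter)). The 3-bromophenyl group also keeps far more growth inhibition than the 4-chloro-3-(trifluoromethyl)phenyl group (a number 31.4 percentage points higher from compound 3 to compound 4 (beyond the scatter)). No evidence at hand explains these steps. Going by these compounds, whether a fluoro, a methoxy or an amine on this ring would sit nearer compound 1 or compound 3 stays open.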